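The source may report more compounds than this note shows. Statements on the series, on what has been measured and on what is new or still open speak of the compounds shown alone.

Measured so far:
compound 1, `Cc1ccccc1N(C)C(=O)c1ccc(-c2ccc(OS(N)(=O)=O)cc2F)o1`, in an assay on T47D cells for inhibition of Steryl-sulfatase (Homo sapiens), read by HPLC, with a stated time of 24 h (a higher number here means a weaker inhibitor, a lower number a stronger inhibitor), compound 1 gives 12 nM.
compound 2, `Cc1ccc(F)cc1N(C)C(=O)c1ccc(-c2ccc(OS(N)(=O)=O)cc2)o1`, in this assay compound 2 gives 40 nM.

Of the two numbers in hand, compound 2 stands at the higher one, and its distance from compound 1 is beyond the usual scatter of this assay, so compound 1 is the stronger inhibitor of the pair. Compound 3, `Cc1ccncc1N(C)C(=O)c1ccc(-c2ccc(OS(N)(=O)=O)cc2)o1`, is not yet measured. It differs from compound 2 in one place: 4-methylpyridin-3-yl in place of 5-fluoro-2-methylphenyl on an amide-type nitrogen. The furan-bearing remainder of the molecule, with its sulfamate, is kept unchanged. For the measured compounds named here, no pair in the set shows what this exchange alone does, so the direction can only be guessed; the expectation is for a change that stays close to the scatter, if anything a slight weakening, so that a 1.3-fold higher number from compound 2 to compound 3 (0.10 log units; within the scatter) is the estimated step in this assay. Compound 3 is therefore expected to give about 50 nM, within a range from 15 nM to 170 nM.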

Compound 3, half-maximal inhibitory concentration: 820 nM
Beside the measured number, compound 3's estimate is 16-fold (1.21 log units) below it; the whole stated range lies below it.
By their numbers in this assay, from the lowest: compound 1; then compound 2; then compound 3.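

In this assay, the group on the amide-type nitrogen proves far from neutral to exchange: 4-methylpyridin-3-yl in place of 5-fluoro-2-methylphenyl brings a 21-fold higher number from compound 2 to compound 3 (1.31 log units; beyond the scatter), while the rest of the molecule stays the same. A single exchange of a ring of carbon only, bearing a fluorine, for a ring with one hetero atom and one hydrogen-bond acceptor is thus enough to produce a large step at this position. Nothing measured here accounts for the size of that step.

The compounds shown do not separate the ring nitrogen from the missing fluorine: compound 3 differs from compound 2 in both. Also open, on these data alone, is how a plain 2-methylphenyl group would read on the core of compound 2, and whether an amine or a methoxy group on this ring would be tolerated.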